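The source may hold more compounds than are shown below. What is called first, only, known or untested is meant among the compounds shown, and "the series" means these compounds.

In a functional assay on SH-SY5Y cells (Homo sapiens) for cytotoxicity, read by MTT assay, with a stated time of 72 h (on this read-out higher numbers stand for weaker inhibition and lower numbers for stronger inhibition), compound 1 (`O=C1c2c[n+]([O-])c3ccccc3c2C(=O)c2c1c1ccccc1n2CCCCn1ccnc1`) gives 130 nM and compound 2 (`CN1CCN(CCCCn2c3c(c4ccccc42)C(=O)c2c[n+]([O-])c4ccccc4c2C3=O)CC1`) gives 100 nM, which is a 1.3-fold lower number from compound 1 to compound 2 (0.11 log units; within the scatter). Compound 3 (`CN1CCN(CCCCCCn2c3c(c4ccccc42)C(=O)c2c[n+]([O-])c4ccccc4c2C3=O)CC1`) has the highest number of the three, at 920 nM. Its distance from the other two is shown by a 7.1-fold higher number from compound 1 to compound 3 (0.85 log units; beyond the scatter) and a 9.2-fold higher number from compound 2 to compound 3 (0.96 log units; beyond the scatter).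

Compound 4 (`CN1CCN(CCCCCn2c3c(c4ccccc42)C(=O)c2c[n+]([O-])c4ccccc4c2C3=O)CC1`) differs from compound 3 by 4-methylpiperazin-1-yl in place of (4-methylpiperazin-1-yl)methyl on a saturated chain carbon, five bonds along the chain from an aromatic nitrogen. Its chain is therefore shorter than that of compound 3 and longer than that of compound 2. The step that bears most directly on this change is a 9.2-fold higher number from compound 2 to compound 3 (0.96 log units; beyond the scatter), since it joins two compounds with the same 4-methylpiperazin-1-yl end group. The step of a 7.1-fold higher number from compound 1 to compound 3 (0.85 log units; beyond the scatter) bears less directly, as compound 1 carries 1H-imidazol-1-yl instead. Among the measured compounds shown here, no measured compound yet shows how the number behaves between the two chain lengths, so a partial return towards compound 2 is expected. The expected change is a 3.1-fold lower number from compound 3 to compound 4 (0.49 log units; beyond the scatter), which is part of that larger step. For compound 4 the estimated value is 300 nM, with an expected range from 110 nM to 800 nM.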

Compound 4, half-maximal inhibitory concentration: 830 nM
Compound 4: middle estimate off by 2.8-fold (0.44 log units), on the low side, outside the stated range (above it).
By their numbers in this assay, from the lowest: compounds 2 and 1 (each within the scatter of the next); then compounds 4 and 3 (each within the scatter of the next).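

In this assay, 4-methylpiperazin-1-yl in place of (4-methylpiperazin-1-yl)methyl, five bonds along the chain from an aromatic nitrogen, gives a 1.1-fold lower number from compound 3 to compound 4 (0.04 log units; within the scatter) and so no readable difference at this position. The gap to the compounds with the shorter chain is already present at compound 4, as an 8.3-fold higher number from compound 2 to compound 4 (0.92 log units; beyond the scatter) and a 6.4-fold higher number from compound 1 to compound 4 (0.81 log units; beyond the scatter) show, so in this series it falls at the single added (4-methylpiperazin-1-yl)methyl step, four bonds along the chain from an aromatic nitrogen, and does not grow with the next extension. Nothing measured accounts for this abrupt step.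

On these data alone, whether a still longer chain keeps the number at this level remains open, as does the effect of a shorter chain. As far as these compounds go, it is also open whether 1H-imidazol-1-yl or a morpholine at the end of the longer chains would follow the same course.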